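Notes on the eight-substituted cyclic nucleotide series

A few compounds are considered here, and "the series" means these few. Any claim that something is new, unique, unknown or untested is made for them only; others in the source may bear on it.

Measured so far:
Compound 1, `CSc1nc2c(N)ncnc2n1[C@@H]1O[C@@H]2COP(=O)(O)O[C@H]2[C@H]1O`: 492%
Compound 2, `[N-]=[N+]=Nc1nc2c(N)ncnc2n1[C@@H]1O[C@@H]2COP(=O)(O)O[C@H]2[C@H]1O`: 227%
Compound 3, `Nc1ncnc2c1nc(S)n2[C@@H]1O[C@@H]2COP(=O)(O)O[C@H]2[C@H]1O`: 136%

All three values come from a functional assay on the whole organism for activation, with Mus musculus as the target, with stated times of 14 days and 2 h, at a dose of 6 mg/kg by the intravenous route; a higher number here means a stronger effect of the compound at the dose given, a lower number a weaker effect. Compound 3 stands lowest of the three, with 136%; its nearest neighbour is compound 2 at 227%, and the furthest is compound 1 at 492%, both steps beyond the scatter.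

Compound 4, `Nc1ncnc2c1nc(N)n2[C@@H]1O[C@@H]2COP(=O)(O)O[C@H]2[C@H]1O`, is not yet measured. The change from compound 3 is amino in place of sulfanyl on an aromatic carbon. Among the compounds with values here, no measured step involves an amino group, so none bears on it directly. All measured steps, however, alter the group on the same aromatic carbon, and every one of them was large: a number 265 percentage points lower from compound 1 to compound 2 (beyond the scatter), a number 356 percentage points lower from compound 1 to compound 3 (beyond the scatter), a number 91 percentage points lower from compound 2 to compound 3 (beyond the scatter). A change at this place is therefore expected to move this assay beyond the scatter, though the direction is open; since compound 3 is the lowest of the series, an upward step is taken as somewhat more likely. For compound 4 the expected step is a number 64 percentage points higher from compound 3 to compound 4 (beyond the scatter). Compound 4 is estimated at 200%, within a range from 100% to 350%.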

Compound 4, a percentage reported as activity, at one dose (the size of the read-out at that dose, not a potency): 226%
Beside the measured number, compound 4's estimate is 26 percentage points below it; low and high end bracket the measured number.
By their numbers in this assay, from the lowest: compound 3; then compounds 4 and 2 (each within the scatter of the next); then compound 1.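

In this assay, amino in place of sulfanyl on this aromatic carbon gives a number 90 percentage points higher from compound 3 to compound 4 (beyond the scatter), although the two groups are alike in the counts of heavy atoms, hydrogen-bond donors and acceptors and in net charge, so these counts alone do not set the read-out here. Unlike every earlier step at this carbon, amino in place of azido leaves the two values indistinguishable, with a number 1 percentage points lower from compound 2 to compound 4 (within the scatter), so a change here does not always move the read-out, while methylsulfanyl remains well separated, with a number 266 percentage points lower from compound 1 to compound 4 (beyond the scatter). Nothing at hand explains these differences.

As far as these compounds go, it remains open whether the high read-out of compound 1 is particular to methylsulfanyl or extends to a longer chain on sulfur, such as ethylsulfanyl or benzylsulfanyl. Also open, from the compounds shown here alone, is how methylamino or dimethylamino would compare with amino, and where a halogen such as bromine would fall.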